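This account rests on a few compounds, and the source may have more. Where it says the series, first, only, none or still open, it means among the compounds named here.

Compound 1, `CN(C)c1ccc(/C=C2\CCC/C(=C\c3ccccc3[N+](=O)[O-])C2=O)cc1`, gives 4.86 in a physicochemical assay for lipophilicity; on this read-out lower numbers stand for lower lipophilicity and higher numbers for higher lipophilicity.
Compound 2, `Cc1ccc(/C=C2\CCC/C(=C\c3ccc([N+](=O)[O-])cc3)C2=O)cc1`, gives 5.08 in this assay.
Compound 3, `O=C1/C(=C/c2ccc(F)cc2)CCC/C1=C\c1ccc([N+](=O)[O-])cc1`, gives 5.08 in this assay.

Compound 3 stands level with compound 2 at the digits shown, and the two sit together at the top of these three numbers; compound 1 lies somewhat lower, but that gap is within the scatter of this kind of measurement, so nothing firm separates the three. The step toward compound 4, `O=C1/C(=C/c2ccc(Cl)cc2)CCC/C1=C\c1ccc([N+](=O)[O-])cc1`, is this: chloro in place of fluoro on an aromatic carbon. Among the compounds with values here, only one measured step touches the same position: no change at the digits printed from compound 2 to compound 3 (within the scatter). That step swapped one small group for another at this spot and left the read-out where it was. A swap of fluoro for chloro is of the same kind, though chloro is the larger halogen. The expectation is therefore a modest rise in this assay, a number 0.32 log units higher from compound 3 to compound 4 (beyond the scatter), rather than none at all. Compound 4 is estimated at 5.4, with a range from 5.1 to 5.8.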

Compound 4, partition coefficient: 5.08
For compound 4 the middle estimate is 0.32 log units above the measured one; the measured number lies below the stated range.
By their numbers in this assay, from the lowest: compounds 1, 2, 3 and 4 (each within the scatter of the next).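

With chloro on this aromatic carbon, this assay shows no change at the digits printed from compound 3 to compound 4 (within the scatter) and also no change at the digits printed from compound 2 to compound 4 (within the scatter). Earlier, only methyl and fluoro could be compared here; now methyl, fluoro and chloro, in compounds 2, 3 and 4, all give read-outs that cannot be told apart, so for these three compounds the choice among the three groups leaves the number unmoved. Nothing available explains why these groups read alike.

From the compounds shown here alone, it remains open whether this holds for a group of a different kind at the same position, such as an amine, a carboxylic acid or a longer chain. Also open, going by these compounds, is whether the same swaps would read alike in the setting of compound 1, which differs from these three in more than one place.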